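Adding Chlorine to Compound 3: Growth Inhibition Expected

The source may report more compounds than this note shows. Statements on the series, on what has been measured and on what is new or still open speak of the compounds shown alone.

Three measured compounds share one core and differ only in the amine on the saturated chain carbon bound to the ring amide nitrogen. In an ADME assay on MCF-10A cells (Homo sapiens) for cytotoxicity, read by sulforhodamine B assay, with a stated time of 48 h (a higher number here means a weaker inhibitor of growth, a lower number a stronger inhibitor of growth), compound 1 `CCN(CC)CN1C(=O)/C(=N\c2nc3ccc(C)cc3s2)c2ccccc21` gives 20400 nM. Compound 2 `Cc1ccc2nc(/N=C3\C(=O)N(CN4CCCCC4)c4ccccc43)sc2c1` gives 38900 nM, and compound 3 `Cc1ccc2nc(/N=C3\C(=O)N(CN(C)C)c4ccccc43)sc2c1` gives 13400 nM. For the measured compounds named here, compound 3 has the lowest of the three numbers, but its gap to compound 1 is within the scatter; only the step of a 2.9-fold lower number from compound 2 to compound 3 (0.46 log units; beyond the scatter) lies beyond it, while a 1.9-fold higher number from compound 1 to compound 2 (0.28 log units; within the scatter) and a 1.5-fold lower number from compound 1 to compound 3 (0.18 log units; within the scatter) do not.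

Compound 4 `Cc1ccc2nc(/N=C3\C(=O)N(CN(C)C)c4cccc(Cl)c43)sc2c1` arises from compound 3 by a change of a different kind: chloro in place of hydrogen on an aromatic carbon. Going by the values given here, none of the measured steps touches the aromatic ring, so none bears directly on this change; together the three steps show that small changes shifted the numbers only modestly. The expected step of a 1.0-fold lower number from compound 3 to compound 4 (0.01 log units; within the scatter) is therefore none beyond the scatter. Compound 4 is estimated at 13000 nM, with a range from 5500 nM to 32000 nM.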

Compound 4, concentration for 50% growth inhibition: 7020 nM
Estimate against measurement, compound 4: 1.9-fold (0.27 log units) above, and the stated range covers the measured number.
By their numbers in this assay, from the lowest: compounds 4, 3, 1 and 2 (each within the scatter of the next, the first and the last beyond it).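

For the compounds shown here, compound 4 gives the first look at the aromatic ring of the shared core, where the amine stays the same and chloro replaces hydrogen on a carbon ortho to a fused ring and meta to a fused ring. In this assay this change gives a 1.9-fold lower number from compound 3 to compound 4 (0.28 log units; within the scatter), so a chlorine atom can sit at this position without a shift that stands clear of the usual variation between repeated measurements. No available evidence offers an explanation for this result.

From the compounds shown here alone, what a fluoro, methoxy or nitrile group would do on this same carbon remains open, as does the effect of chloro on the other carbons of this ring. Going by these compounds, it is also open whether chloro would give a similar result alongside the diethylamino group of compound 1 or the piperidin-1-yl group of compound 2.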